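Swapping the ester for a phenyl on the triazole ring

A few compounds are considered here, and "the series" means these few. Any claim that something is new, unique, unknown or untested is made for them only; others in the source may bear on it.

In a functional assay on MCF7 cells (Homo sapiens) for cytotoxicity, read by MTT assay, with a stated time of 72 h (a higher number here means a weaker inhibitor, a lower number a stronger inhibitor), compound 3 `CCOC(=O)c1cn(Cc2nnc(-c3cc(S(N)(=O)=O)c(SCc4ccccc4)cc3Cl)o2)nn1` gives 150000 nM. It stands second highest of three: compound 1 `NS(=O)(=O)c1cc(-c2nnc(CN3CCC(Cc4ccccc4)CC3)o2)c(Cl)cc1SCc1ccccc1` gives 170000 nM, a gap within the scatter, while compound 2 `[N-]=[N+]=NCc1nnc(-c2cc(S(N)(=O)=O)c(SCc3ccccc3)cc2Cl)o1` gives 55000 nM, beyond the scatter. The only single-site step among these is a 2.7-fold higher number from compound 2 to compound 3 (0.44 log units; beyond the scatter), which builds the five-membered aromatic ring with 3 nitrogen rather than altering what sits on it. Compound 4 `NS(=O)(=O)c1cc(-c2nnc(Cn3cc(-c4ccccc4)nn3)o2)c(Cl)cc1SCc1ccccc1` differs from compound 3 by phenyl in place of ethoxycarbonyl on an aromatic carbon. Within the data shown here, no measured step trades an ester for an aromatic ring at that position, so no step beyond the scatter is expected in this assay. The expected step is no change at the digits printed from compound 3 to compound 4 (within the scatter). Compound 4 is estimated at 150000 nM, with a range from 50000 nM to 400000 nM.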

Compound 4, half-maximal inhibitory concentration: 170000 nM
Beside the measured number, compound 4's estimate is 1.1-fold (0.05 log units) below it, and the stated range covers the measured number.
By their numbers in this assay, from the lowest: compound 2; then compounds 3, 1 and 4 (each within the scatter of the next).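

In this assay, phenyl in place of ethoxycarbonyl gives a 1.1-fold higher number from compound 3 to compound 4 (0.05 log units; within the scatter) on this aromatic carbon, so an ester with hydrogen-bond acceptors and a carbon-only aromatic ring without them read alike here. Replacing azido with 4-phenyl-1H-1,2,3-triazol-1-yl gives a 3.1-fold higher number from compound 2 to compound 4 (0.49 log units; beyond the scatter) in this assay, so the higher number seen with the ethoxycarbonyl triazole also appears with the phenyl triazole. No measurement here explains either result. Still open, on these data alone, is whether an amine or a carboxylic acid at this carbon would move the number beyond the scatter.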